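Amino Nitrogen Elaborated: From Compound 2 to Compound 4

A few compounds are considered here, and "the series" means these few. Any claim that something is new, unique, unknown or untested is made for them only; others in the source may bear on it.

Compound 1 `COc1ccc(CS(=O)(=O)/C=C/c2c(OC)cc(OC)cc2OC)c(N)c1`: 25 nM
Compound 2 `COc1cc(OC)c(/C=C/S(=O)(=O)Cc2ccc(OC)c(N)c2)c(OC)c1`: 2.5 nM
Compound 3 `COc1cc(OC)c(/C=C/S(=O)(=O)Cc2ccc(Cl)c(N)c2)c(OC)c1`: 10 nM

In a functional assay on K562 cells (Homo sapiens) for cytotoxicity, read by trypan blue exclusion, with a stated time of 96 h (on this read-out higher numbers stand for weaker inhibition and lower numbers for stronger inhibition), compound 2 gives 2.5 nM, the lowest number of the three. The step of a 10-fold lower number from compound 1 to compound 2 (1.00 log units; beyond the scatter) separates it from compound 1, and the step of a 4.0-fold higher number from compound 2 to compound 3 (0.60 log units; beyond the scatter) separates it from compound 3, so compound 2 stands apart from both by more than the scatter.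

Compound 4 `COc1cc(OC)c(/C=C/S(=O)(=O)Cc2ccc(OC)c(NC(F)(F)C(=O)O)c2)c(OC)c1` differs from compound 2 by carboxy(difluoro)methyl in place of hydrogen on a nitrogen on an aromatic ring. Neither measured step bears directly on this change: the step from compound 1 to compound 2 moves the amino group on the ring, and the step from compound 2 to compound 3 swaps a ring substituent, while the nitrogen itself stays bare in all three. Both measured steps are modest, and nothing here shows what substitution on that nitrogen does. A modest step, more likely toward a higher number than a lower one, is expected, with wide uncertainty. The estimate for compound 4 is therefore 12 nM, in the range 3 nM to 60 nM, which amounts to an expected step of a 4.8-fold higher number from compound 2 to compound 4 (0.68 log units; beyond the scatter).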

Compound 4, half-maximal inhibitory concentration: 150 nM
Beside the measured number, compound 4's estimate is 13-fold (1.10 log units) below it; measured number outside the range, above it.
By their numbers in this assay, from the lowest: compound 2; then compound 3; then compound 1; then compound 4.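

In this assay, carboxy(difluoro)methyl in place of hydrogen on the nitrogen gives a 60-fold higher number from compound 2 to compound 4 (1.78 log units; beyond the scatter) and is the first change shown at the nitrogen itself. The earlier steps shown here, all with that nitrogen bare, were modest, whereas this one is large, so the nitrogen of compound 2 does not tolerate this substituent without a clear loss in this read-out. Nothing measured here accounts for the size of the step.

The compounds shown leave open whether the step follows from the carboxylic acid, the two fluorines or simply a substituent on the nitrogen; a methyl group, an acetyl amide or a plain carboxymethyl group there would separate these. They also leave open whether the same group on the nitrogen of compound 1 or compound 3 would bring a step of similar size.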